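This account rests on a few compounds, and the source may have more. Where it says the series, first, only, none or still open, it means among the compounds named here.

Three compounds have been run in a functional assay on the whole organism (strain Wistar Albino) for inhibition, with Rattus norvegicus as the target, read by paw edema, with a stated time of 3 h, at a dose of 20 mg/kg; a higher number here means more inhibition at the dose given (going by the name of the read-out), a lower number less inhibition. Compound 1, `Cc1cc(-c2nn3c(-c4ccoc4C)nnc3s2)c2ccccc2n1`, gives 18.6% in this assay. Compound 2, `Cc1occc1-c1nnc2sc(-c3ccnc4ccccc34)nn12`, gives 20.3% in this assay. Compound 3, `COc1ccc2[nH]cc(Cc3nn4c(Cc5ccc(OC)c(OC)c5)nnc4s3)c2c1`, gives 19.1% in this assay, a number that sits beside those of compound 1 and compound 2 within the scatter. The difference between the core of compound 2 and the core of compound 3 is not broken down here.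

Compound 1 and compound 2 differ in one place, (methyl in place of hydrogen on an aromatic carbon), and the step of a number 1.7 percentage points lower from compound 2 to compound 1 (within the scatter) lies within the scatter.

Compound 4, `COc1ccc2[nH]c(C)c(Cc3nn4c(Cc5ccc(OC)c(OC)c5)nnc4s3)c2c1`, has not yet been measured. It differs from compound 3 by methyl in place of hydrogen on an aromatic carbon. This is the same kind of change as that from compound 2 to compound 1, but the surroundings are not the same: in compound 4 the methyl enters on an aromatic carbon of a five-membered aromatic ring with 1 nitrogen, next to the ring nitrogen and next to the ring atom that bears a large group, whereas in compound 1 it enters on a six-membered aromatic ring with 1 nitrogen, meta to a fused ring, meta to a large group and para to a fused ring.

Going by the values given here, since the one measured instance of this change, a number 1.7 percentage points lower from compound 2 to compound 1 (within the scatter), lies within the scatter, the step from compound 3 to compound 4 is expected to be of a similar size, about a number 0.1 percentage points lower from compound 3 to compound 4 (within the scatter) in this assay. Compound 4 is therefore estimated to give 19% in this assay, with a range from 8% to 30%.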

Compound 4, a percentage reported as inhibition, in the whole organism at one dose (the size of the read-out at that dose, not a potency): 21.4%
The estimate for compound 4 lay 2.4 percentage points below the measured number; the measured number falls inside the stated range.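

In this assay, the change of methyl in place of hydrogen on an aromatic carbon now has a second reading, a number 2.3 percentage points higher from compound 3 to compound 4 (within the scatter), and set beside the first reading the two do not separate: the same change on two cores in this assay, a number 1.7 percentage points lower (within the scatter) from compound 2 to compound 1 and a number 2.3 percentage points higher (within the scatter) from compound 3 to compound 4, 4 percentage points apart, within the scatter of two such steps.
So on both cores shown, the change gives a step that stays inside the usual scatter, and the opposite directions of the two steps carry no weight. This does not show that the methyl is without effect in this series or that the two cores respond to it alike, since two small steps cannot tell a true shared effect, or a true difference between the cores, from the spread of repeated measurements.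

The compounds shown hold only hydrogen or methyl at these places, so it stays open whether a longer chain, an amine or a carboxylic acid there would give a step beyond the scatter in this assay. As far as these compounds go, it also stays open whether the methyl step would stand out on the two cores at another dose or at another reading time.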